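Chloro on the distal ring in two sulfonyl-linked cores

The compounds below may be only part of what the source reports. "The series", "measured", "known", "first", "only" and "open" are said of these compounds alone.

Measured compounds:
compound 1, `CC(C)c1ccc2c(CCCS(=O)(=O)Nc3ccccc3)cc(S(=O)(=O)O)c-2cc1`, 8700 nM in a functional assay on thoracic aorta for antagonist activity at thromboxane A2 receptor (Rattus norvegicus); a higher number here means a weaker inhibitor, a lower number a stronger inhibitor;
compound 2, `CC(C)c1ccc2c(CCCS(=O)(=O)Nc3ccc(Cl)cc3)cc(S(=O)(=O)O)c-2cc1`, 860 nM;
compound 3, `CC(C)c1ccc2c(CCCC(=O)NS(=O)(=O)c3ccccc3)cc(C(=O)O)c-2cc1`, a limit of the assay, > 100000 nM.

Compounds 1 and 2 share a core and differ by chloro in place of hydrogen on an aromatic carbon; that change gave a 10-fold lower number from compound 1 to compound 2 (1.01 log units; beyond the scatter). Compound 3 carries a different core; how it differs from compound 1 is not broken down here. For compound 3 only a limit is known, the one stated in the limit of > 100000 nM in this assay, at which 1 of the 3 values shown sits. Compound 4, `CC(C)c1ccc2c(CCCC(=O)NS(=O)(=O)c3ccc(Cl)cc3)cc(C(=O)O)c-2cc1`, is not yet measured; it differs from compound 3 by chloro in place of hydrogen on an aromatic carbon, the same change seen in the first pair. Because the first pair showed a 10-fold lower number from compound 1 to compound 2 (1.01 log units; beyond the scatter), the step is expected to be an at least 2.5-fold lower number from compound 3 to compound 4 (0.39 log units; beyond the scatter). Since compound 3 sits at a limit, compound 4 may also return only a limit. For compound 4 the estimate is 40000 nM, between 8000 nM and 200000 nM.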

Compound 4, half-maximal inhibitory concentration: 19000 nM
For compound 4 the middle estimate is 2.1-fold (0.32 log units) above the measured one; the measured number falls inside the stated range.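

Chloro in place of hydrogen, read as phenyl to 4-chlorophenyl, in this assay gave an at least 5.2-fold lower number from compound 3 to compound 4 (0.72 log units; beyond the scatter), so the direction of the step held on both cores shown. The value of compound 3 is a limit of the assay, > 100000 nM. This shows a shared direction on these two cores only, and it does not show that the change is worth the same amount on each: the same change on two cores in this assay, a 10-fold lower number (1.01 log units; beyond the scatter) from compound 1 to compound 2 and an at least 5.2-fold lower number (0.72 log units; beyond the scatter) from compound 3 to compound 4; the limit leaves it open whether they differ.

The compounds shown leave open whether fluoro, bromo or methyl in place of the chloro would give a step in the same direction. They also leave open whether the chloro step would hold on a core with a longer chain.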